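The source may hold more compounds than are shown below. What is called first, only, known or untested is meant among the compounds shown, and "the series" means these compounds.

Of the compounds shown here, two with a shared core have been measured in a functional assay for agonist activity at Glucose-dependent insulinotropic receptor (Mus musculus), read by cAMP accumulation; a lower number here means that less compound is needed, a higher number that more compound is needed for the effect. Compound 1 `CC1(OC(=O)N2CC3COCC(C2)C3Oc2ncnc(Nc3ccc(F)cc3F)c2F)CC1` gives 44 nM in this assay. Among the compounds with values here, compound 2 `CCC1(OC(=O)N2CC3COCC(C2)C3Oc2ncnc(Nc3ccc(C#N)cc3F)c2F)CC1` gives 43 nM in this assay, a number that sits within the usual scatter of the one seen for compound 1, so the two cannot be told apart on these data. Compound 3 `COCC1(OC(=O)N2CC3COCC(C2)C3Oc2ncnc(Nc3ccc(C#N)cc3F)c2F)CC1` has not yet been measured; it differs from compound 2 in a single spot: methoxy in place of methyl on a saturated chain carbon bound to a saturated ring carbon. Within the data shown here, no comparable step between two measured compounds is available here, so there is no measured precedent for this change. With the two measured numbers lying so close together, no step beyond the scatter is expected from this small change at the outer end of the chain. The step from compound 2 to compound 3 is therefore estimated as a 1.3-fold higher number from compound 2 to compound 3 (0.11 log units; within the scatter). Compound 3 is expected to give about 55 nM in this assay, with a likely range from 22 nM to 140 nM.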

Compound 3, half-maximal effective concentration: 312 nM
Beside the measured number, compound 3's estimate is 5.7-fold (0.75 log units) below it, and the stated range ends below it.
By their numbers in this assay, from the lowest: compounds 2 and 1 (each within the scatter of the next); then compound 3.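

In this assay, placing methoxy in place of methyl on a saturated chain carbon bound to a saturated ring carbon gives a 7.3-fold higher number from compound 2 to compound 3 (0.86 log units; beyond the scatter). Within the data shown here, this is the first step that can be read at all, and it shows that the outer end of this chain is not indifferent to what sits there: going from ethyl to methoxymethyl means that more compound is needed for the effect. Nothing available here accounts for this rise. On these data alone, what remains open is whether the oxygen itself or simply the greater chain length matters, and a propyl group at this spot would separate the two. Also open, as far as these compounds go, is how a hydroxyl or an amine at the end of this chain would compare.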